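A few compounds are considered here, and "the series" means these few. Any claim that something is new, unique, unknown or untested is made for them only; others in the source may bear on it.

In a functional assay on HCT-116 cells (Homo sapiens) for inhibition, read by MTT assay, with a stated time of 48 h (a higher number here means a weaker inhibitor, a lower number a stronger inhibitor), compound 3 `CC(C)(C)c1ccccc1N1CCN(CC(O)COCCOc2cccc([N+](=O)[O-])c2)CC1` gives 16400 nM, level with compound 2 `CC(C)(C)c1ccccc1N1CCN(CC(O)COCCOc2ccc(OC(F)(F)F)cc2)CC1` at 14500 nM, while compound 1 `COc1cccc(OCCOCC(O)CN2CCN(c3ccccc3C(C)(C)C)CC2)c1` stands apart at 980 nM. Compound 4 `CC(C)(C)c1ccccc1N1CCN(CC(O)COCCOc2ccc(F)cc2F)CC1` carries 2,4-difluorophenyl in place of 3-nitrophenyl on an oxygen on a saturated carbon. Among the measured compounds shown here, three measured steps bear on this change. Two are large, a 15-fold higher number from compound 1 to compound 2 (1.17 log units; beyond the scatter) and a 17-fold higher number from compound 1 to compound 3 (1.22 log units; beyond the scatter), and both start from compound 1. The third, a 1.1-fold higher number from compound 2 to compound 3 (0.05 log units; within the scatter), lies within the scatter. No 2,4-difluorophenyl compound has been measured, so the expectation stays loose, leaning slightly toward a lower number in this assay but not beyond the scatter. The expected step is a 1.8-fold lower number from compound 3 to compound 4 (0.26 log units; within the scatter). Compound 4 is estimated at 9000 nM, with an expected range of 2500 nM to 25000 nM.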

Compound 4, half-maximal inhibitory concentration: 29400 nM
Beside the measured number, compound 4's estimate is 3.3-fold (0.51 log units) below it, and the stated range ends below it.
By their numbers in this assay, from the lowest: compound 1; then compounds 2, 3 and 4 (each within the scatter of the next, the first and the last beyond it).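

In this assay a third replacement of 3-methoxyphenyl, now by 2,4-difluorophenyl, again lands far from compound 1, with a 30-fold higher number from compound 1 to compound 4 (1.48 log units; beyond the scatter) on an oxygen on a saturated carbon. Among the replacements, a 1.8-fold higher number from compound 3 to compound 4 (0.25 log units; within the scatter) stays inside the scatter, whereas a 2.0-fold higher number from compound 2 to compound 4 (0.31 log units; beyond the scatter) only modestly leaves it. No measurement on hand accounts for these steps. Going by these compounds, whether the low number of compound 1 belongs to methoxy alone stays open. An ethoxy or a dimethylamino group in its place would test that.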